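This account rests on a few compounds, and the source may have more. Where it says the series, first, only, none or still open, it means among the compounds named here.

Compound 1 `Cc1ccc(C(CC/N=C(\N)NCCCc2c[nH]cn2)c2ccccn2)cc1` gives 1 in a functional assay on cardiac atrium for agonist activity at histamine H2 receptor (Cavia porcellus); on this read-out lower numbers stand for smaller maximal responses and higher numbers for larger maximal responses.
Compound 2 `N=C(NCCCc1c[nH]cn1)NCCC(c1ccc(Cl)cc1)c1ccccn1` gives 1 in this assay.

Compound 2 stands level with compound 1 at the digits shown, within the usual scatter, so the two show no difference in this read-out. Compound 3 `N=C(NCCCc1c[nH]cn1)NCCC(c1cc(F)cc(F)c1)c1ccccn1` differs from compound 2 in one place: 3,5-difluorophenyl in place of 4-chlorophenyl on a saturated chain carbon bound to an aromatic carbon and a saturated chain carbon. For the measured compounds named here, no measured pair here shows what such a change does, so no step is known to lean on. Because compound 2 gives 1, compound 3 is expected to move by a number 0.050 lower from compound 2 to compound 3 (within the scatter), a step not beyond the scatter. Compound 3 is estimated at 0.95, expected to lie between 0.8 and 1.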

Compound 3, intrinsic activity: the largest response reached, as a fraction of the reference agonist's: 1
The estimate for compound 3 lay 0.050 below the measured number; the range from low to high includes it.
By their numbers in this assay, from the lowest: compounds 1, 2 and 3 (each within the scatter of the next).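

In this assay there is no change at the digits printed from compound 2 to compound 3 (within the scatter) when 3,5-difluorophenyl takes the place of 4-chlorophenyl on a saturated chain carbon bound to an aromatic carbon and a saturated chain carbon. For the compounds shown here, this is the first one-place comparison, and it shows that this swap of ring substituents leaves the maximal response level. Nothing available accounts for this result. Still open, from the compounds shown here alone, is whether the response would hold with an amine or a carboxylic acid in place of the substituted phenyl ring at this saturated chain carbon.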